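Swapping hydroxy for cyano on the aromatic ring

A few compounds are considered here, and "the series" means these few. Any claim that something is new, unique, unknown or untested is made for them only; others in the source may bear on it.

Measured in a functional assay on A549 cells (Homo sapiens) for inhibition, read by CCK-8 assay, with a stated time of 72 h, tested at 1 uM; a lower number here means less inhibition of growth, a higher number more inhibition of growth at the concentration tested:
compound 1 `Cc1cccc(NC(=O)C2(C(=O)Nc3ccc(Nc4ncc5cc(C(=O)N(C)C)n(C6CCCC6)c5n4)cc3)CC2)c1`: 35.2%
compound 2 `CN(C)C(=O)c1cc2cnc(Nc3ccc(NC(=O)C4(C(=O)Nc5ccc(O)cc5)CC4)cc3)nc2n1C1CCCC1`: 93.6%

Of the two measured compounds, compound 2 holds the higher number, at 93.6%. Compound 3 `CN(C)C(=O)c1cc2cnc(Nc3ccc(NC(=O)C4(C(=O)Nc5ccc(C#N)cc5)CC4)cc3)nc2n1C1CCCC1` carries cyano in place of hydroxy on an aromatic carbon, para to a large group: cyano in place of hydroxy on an aromatic carbon. Going by the values given here, one measured step bears on this ring: a number 58.4 percentage points higher from compound 1 to compound 2 (beyond the scatter). Among the compounds with values here, no measured compound carries cyano, so this large step guides the estimate only loosely. Compound 1, which also has no hydroxy, gives 35.2% in this assay, so a sizeable fall is expected. The estimate is a number 31.6 percentage points lower from compound 2 to compound 3 (beyond the scatter). Compound 3 is expected at 62%, within a range of 30% to 90%.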

Compound 3, percent growth inhibition at one concentration: 86.1%
Compound 3: the middle estimate sits 24.1 percentage points below what was measured, and the stated range covers the measured number.
By their numbers in this assay, from the lowest: compound 1; then compounds 3 and 2 (each within the scatter of the next).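

In this assay, cyano in place of hydroxy gives a number 7.5 percentage points lower from compound 2 to compound 3 (within the scatter), so on this aromatic carbon, para to a large group, a group with 0 hydrogen-bond donors reads the same as hydroxy within the scatter. The 4-cyanophenyl in place of 3-methylphenyl gives a number 50.9 percentage points higher from compound 1 to compound 3 (beyond the scatter), so the large gain over compound 1 is not confined to 4-hydroxyphenyl. Nothing measured here explains why the two groups read alike. Going by these compounds, it remains open whether an amine or a carboxylic acid on the same carbon would keep this level. Compound 1 also differs from both in where its substituent sits and in which group it carries, so these two changes cannot be told apart.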